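This account rests on a few compounds, and the source may have more. Where it says the series, first, only, none or still open, it means among the compounds named here.

The study concerns cytotoxicity measured in a functional assay on OE21 cells (Homo sapiens) for cytotoxicity, read by MTT assay, with a stated time of 72 h; a lower number here means a stronger inhibitor, a higher number a weaker inhibitor. Among the compounds with values here, compound 1, `CC(C)=CCOc1ccc(C(=O)/C=C/c2ccc(O)cc2)c(O)c1`, is the only member of the set with a real number: in this assay compound 1 gives 58000 nM. Compound 2, `C=C(C)CCOc1ccc(C(=O)O)cc1OC`, returns in this assay only a limit of the assay, > 100000 nM, and not a number. Within the data shown here, that limit, (the limit of > 100000 nM in this assay, at which 1 of the 2 values shown sits), is the sole other entry, so compound 1 stands alone and no step between measured compounds can be read from these data.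

Compound 3, `CC(C)=CCOc1ccc(C(=O)/C=C/c2ccccc2)c(O)c1`, remains to be tested. It differs from compound 1 in a single place: hydrogen in place of hydroxy on an aromatic carbon. In this assay the step from compound 1 to compound 3 is expected to be small, in either direction no larger than the usual scatter or at most a modest weakening. Among the measured compounds shown here, no measured pair here tells what the hydroxy contributes. The expected step is a 1.2-fold higher number from compound 1 to compound 3 (0.08 log units; within the scatter). Compound 3 is therefore estimated at roughly 70000 nM, with a plausible range from 25000 nM to 200000 nM.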

Compound 3, half-maximal inhibitory concentration: 39000 nM
Compound 3: middle estimate off by 1.8-fold (0.25 log units), on the high side; measured number inside the range.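

Within the data shown here, the hydroxy on the aromatic carbon para to a large group is the first place in the set where a step can be read in this assay, and the change from 4-hydroxyphenyl to phenyl gives a 1.5-fold lower number from compound 1 to compound 3 (0.17 log units; within the scatter). The earlier compounds shown here could not show this, since compound 1 had no measured partner that differed from it in one place. The pair shows that, in this assay, losing this hydroxy, with its one hydrogen-bond donor and one hydrogen-bond acceptor, leaves a number that cannot be told apart from that of compound 1, yet nothing given here bears on why the two compounds read alike.

On these data alone, whether a different group in this place, such as a methoxy, an amine, a carboxylic acid or a fluorine, would move the number beyond the scatter remains open. As far as these compounds go, it is also open whether the hydroxy would matter as little with a longer chain or an amine in place of the ether chain of the shared core.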